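The source may hold more compounds than are shown below. What is called first, only, known or untested is meant among the compounds shown, and "the series" means these compounds.

In an ADME assay on 184B5 cells (Homo sapiens) for cytotoxicity, read by MTT assay, with a stated time of 72 h (on this read-out higher numbers stand for weaker inhibition of growth and lower numbers for stronger inhibition of growth), compound 1 `CSc1ccc(CNc2nc(SC)nc3ncccc23)cc1` gives 190 nM, the lowest of the two numbers obtained, and it stands far from compound 2 `CSc1nc(NCc2ccccc2)c2ccccc2n1`, which in this assay gives 28900 nM. Compound 3 `CCCCCSc1nc(O)c2ccccc2n1` returns in this assay only a limit of the assay, > 100000 nM. For the measured compounds named here, no two of these measured compounds differ in a single place, so no single step among them has been measured; what is known beyond the two numbers is the limit of > 100000 nM in this assay, at which 1 of the 3 values shown sits. Compound 4 `CSc1nc(NCc2ccccc2)c2cccnc2n1` is the one not yet measured. It differs from compound 1 by hydrogen in place of methylsulfanyl on an aromatic carbon. Going by the values given here, with no measured step to lean on, the size of this change in this assay is open, but compound 2 also lacks the methylsulfanyl group on a different core and gives 28900 nM, which suggests a shift toward weaker inhibition beyond the scatter rather than none. Compound 4 is therefore expected to give about 3000 nM in this assay, somewhere from 500 nM to 30000 nM. That estimate would mean a step of a 16-fold higher number from compound 1 to compound 4 (1.20 log units; beyond the scatter), expected to run toward weaker inhibition of growth.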

Compound 4, concentration for 50% growth inhibition: 49000 nM
Compound 4: middle estimate off by 16-fold (1.21 log units), on the low side; measured number outside the range, above it.
By their numbers in this assay, from the lowest: compound 1; then compounds 2 and 4 (each within the scatter of the next). At a limit, above all of these: compound 3.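

Replacing the methylsulfanyl group with hydrogen on this aromatic carbon, para to a large group, gives a 260-fold higher number from compound 1 to compound 4 (2.41 log units; beyond the scatter) in this assay, and this is the only single change among the compounds shown. It shows that this place on the six-membered aromatic ring of carbon only is not indifferent: with the rest of the structure unchanged, the choice between methylsulfanyl and hydrogen moves the number far beyond the scatter, toward weaker inhibition of growth. Nothing measured here accounts for the size of this step.

The compounds shown leave open whether the large step belongs to methylsulfanyl in particular, or whether a methoxy group, a chlorine atom or a longer chain on the sulfur at this carbon would keep the number close to that of compound 1 at 190 nM. They also leave open whether the same exchange would carry the same weight on a different core, and what an amine would do in place of the other methylsulfanyl group, the one on the core shared by compound 1 and compound 4.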